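Shifting the methyl on the benzyl group of compound 2

A few compounds are considered here, and "the series" means these few. Any claim that something is new, unique, unknown or untested is made for them only; others in the source may bear on it.

Two compounds share one core, a benzoxazolone-bearing chain ending in a methylated amine that carries a substituted benzyl group. Compound 1 `Cc1ccc(CN(C)CCCCn2c(=O)oc3ccccc32)c(C)c1` is tested in an assay on membranes from liver for displacement of a labelled ligand from Sigma non-opioid intracellular receptor 1 (Rattus norvegicus), read by scintillation counting (on this read-out lower numbers stand for stronger inhibition and higher numbers for weaker inhibition), and gives 239 nM. Compound 2 `Cc1cccc(CN(C)CCCCn2c(=O)oc3ccccc32)c1` in this assay gives 102 nM. Within the data shown here, the step of a 2.3-fold lower number from compound 1 to compound 2 (0.37 log units; beyond the scatter) is the only measured change, and it places compound 2 at the lowest of the two numbers so far, with compound 1 as its only neighbour.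

Compound 3 `Cc1ccc(CN(C)CCCCn2c(=O)oc3ccccc32)cc1` is not yet measured. It differs from compound 2 by 4-methylphenyl in place of 3-methylphenyl on a saturated chain carbon bound to an amine nitrogen. Among the measured compounds shown here, only one step bears on this change: the step of a 2.3-fold lower number from compound 1 to compound 2 (0.37 log units; beyond the scatter), which altered the methyl pattern on the same aryl ring and produced a modest shift. That step removed a methyl as well as moving one, so it is an imperfect guide; the present change keeps the atom count and merely moves a single methyl. The expected step of a 1.5-fold higher number from compound 2 to compound 3 (0.17 log units; within the scatter) is therefore small, most likely within the scatter, with a slight lean toward a higher number. Compound 3 is expected to give 150 nM in this assay, with a range from 60 nM to 400 nM.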

Compound 3, inhibition constant: 97 nM
For compound 3 the middle estimate is 1.5-fold (0.19 log units) above the measured one, and the stated range covers the measured number.
By their numbers in this assay, from the lowest: compounds 3 and 2 (each within the scatter of the next); then compound 1.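

In this assay, moving the single methyl from 3-methylbenzyl to 4-methylbenzyl gives a 1.1-fold lower number from compound 2 to compound 3 (0.02 log units; within the scatter) and so does not separate these two placements on a saturated chain carbon bound to an amine nitrogen. The earlier step from the 2,4-dimethylphenyl group to 3-methylphenyl removed one methyl and moved another, whereas hydrogen in place of methyl on an aromatic carbon gives a 2.5-fold lower number from compound 1 to compound 3 (0.39 log units; beyond the scatter) as a clean removal of one methyl, and this step, like a 2.3-fold lower number from compound 1 to compound 2 (0.37 log units; beyond the scatter) before it, is beyond the scatter. Among these three compounds, the two with one methyl on the ring therefore sit together and apart from compound 1 with its two methyls, although no measured evidence on the cause of this is at hand.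

The compounds shown leave open how a 2-methylphenyl group, or a plain phenyl group with no methyl at all, would fare in this assay on this same chain carbon. They also leave open whether a chloro or methoxy group in place of the methyl, or a longer chain in the shared core, would keep the numbers in this range.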